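This account rests on a few compounds, and the source may have more. Where it says the series, first, only, none or still open, it means among the compounds named here.

Of the compounds shown here, three on a shared core have been read in a functional assay on MDA-MB-231 cells (Homo sapiens) for cytotoxicity, read by MTT assay; on this read-out lower numbers stand for stronger inhibition and higher numbers for weaker inhibition: compound 1 (`COc1cccc(/C=C2\CCC/C(=C\c3cccc([N+](=O)[O-])c3)C2=O)c1`) gives 13.2 ug/mL, compound 2 (`O=C1/C(=C/c2ccc([N+](=O)[O-])cc2)CCC/C1=C\c1cccc([N+](=O)[O-])c1`) gives 8.85 ug/mL and compound 3 (`O=C1/C(=C/c2cccc(Cl)c2)CCC/C1=C\c1cccc([N+](=O)[O-])c1`) gives 5.01 ug/mL. Compound 2 holds the second highest of these three numbers, but it lies within the scatter of both others, as a 1.5-fold lower number from compound 1 to compound 2 (0.17 log units; within the scatter) and a 1.8-fold lower number from compound 2 to compound 3 (0.25 log units; within the scatter) show. Only a 2.6-fold lower number from compound 1 to compound 3 (0.42 log units; beyond the scatter) goes beyond the scatter, and it is modest.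

Compound 4 (`O=C1/C(=C/c2ccc(Cl)cc2)CCC/C1=C\c1ccc([N+](=O)[O-])cc1`) differs from compound 2 by 4-chlorophenyl in place of 3-nitrophenyl on a double-bonded chain carbon bound to a double-bonded ring carbon. The closest measured precedent is the step to compound 3, which also exchanges a nitrophenyl for a chlorophenyl at this kind of carbon, though with different groups, and it stayed within the scatter. The step expected in this assay is therefore a 1.5-fold lower number from compound 2 to compound 4 (0.17 log units; within the scatter), a small move towards lower numbers that stays within the scatter. The estimated value for compound 4 is 6 ug/mL, with an expected range of 2.5 ug/mL to 14 ug/mL.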

Compound 4, half-maximal inhibitory concentration: 12.4 ug/mL
The estimate for compound 4 lay 2.1-fold (0.32 log units) below the measured number; measured number inside the range.
By their numbers in this assay, from the lowest: compounds 3, 2, 4 and 1 (each within the scatter of the next, the first and the last beyond it).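

Compound 1, compound 2 and compound 3 all carry 3-nitrophenyl, so compound 4 is the only one shown without it. In this assay, replacing that group with 4-chlorophenyl on a double-bonded chain carbon bound to a double-bonded ring carbon gives a 1.4-fold higher number from compound 2 to compound 4 (0.15 log units; within the scatter), so 3-nitrophenyl is not required at this position for a number in this range, and the exchange of nitro-bearing for chloro-bearing phenyl is tolerated here. No measurement on hand accounts for this outcome.

Going by these compounds, whether any change at this position can move the number beyond the scatter remains open. Also open, on these data alone, is how the read-out responds to groups other than substituted phenyl rings with nitro, chloro or methoxy, such as a phenyl ring bearing an amine or a carboxylic acid, or a longer alkyl chain.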